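The compounds below may be only part of what the source reports. "The series", "measured", "known", "first", "only" and "open" are said of these compounds alone.

Measured in a functional assay on MT4 cells (Homo sapiens) for cytotoxicity, read by CellTiter-Glo, with a stated time of 5 days; on this read-out higher numbers stand for an effect only at larger amounts of compound and lower numbers for an effect already at smaller amounts:
compound 1 `Cc1ccc(-c2c(C)noc2C)cc1S(=O)(=O)NC1CCCC1`: 1590 nM
compound 2 `Cc1ccc2ncccc2c1-c1cc(-c2c(C)noc2C)cc2nc(C3CC3)[nH]c12`: 18 nM
compound 3 `Cc1ccc(-c2cnoc2)cc1S(=O)(=O)NC1CCCC1`: 43200 nM

Of these three, compound 3 gives the highest number, 43200 nM. Compound 1 lies nearest to it and compound 2 furthest away. Compound 4 `Cc1ccc(-c2c(C)n[nH]c2C)cc1S(=O)(=O)NC1CCCC1` keeps the rest of compound 3 and changes one group, which sits on an aromatic carbon para to a methyl group: 3,5-dimethyl-1H-pyrazol-4-yl in place of 1,2-oxazol-4-yl on an aromatic carbon.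

Within the data shown here, one measured step bears on this change: a 27-fold higher number from compound 1 to compound 3 (1.43 log units; beyond the scatter), which is large and beyond the scatter. That step replaces 3,5-dimethyl-1,2-oxazol-4-yl with 1,2-oxazol-4-yl, so it removes the methyl groups that the new change brings back, though on a different ring. Among the measured compounds shown here, no measured step shows what exchanging the 1,2-oxazole ring for the 1H-pyrazole ring does on its own. For the measured compounds named here, compound 2, at 18 nM, differs from the others in much more than this group and gives no step to draw on.

A move toward a lower number in this assay is therefore expected, recovering much but not all of the measured step. The expected step is an 8.6-fold lower number from compound 3 to compound 4 (0.94 log units; beyond the scatter). For compound 4 the estimated value is 5000 nM, with an expected range from 1500 nM to 20000 nM.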

Compound 4, half-maximal effective concentration: 5420 nM
Compound 4: middle estimate off by 1.1-fold (0.04 log units), on the low side; measured number inside the range.
By their numbers in this assay, from the lowest: compound 2; then compound 1; then compound 4; then compound 3.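

In this assay, an 8.0-fold lower number from compound 3 to compound 4 (0.90 log units; beyond the scatter), which shows that a second ring carrying two methyl groups also brings the number down at this aromatic carbon, para to a methyl group, although this step changes the ring and adds the methyl groups together. Among these compounds, with both methyl groups kept, a 3.4-fold higher number from compound 1 to compound 4 (0.53 log units; beyond the scatter), and this gives what the earlier compounds could not: the exchange of the 1,2-oxazole ring for the 1H-pyrazole ring on its own, which is beyond the scatter and leaves the 3,5-dimethyl-1,2-oxazol-4-yl compound with the lower number. That exchange counts for less than the loss of the two methyl groups seen in a 27-fold higher number from compound 1 to compound 3 (1.43 log units; beyond the scatter), but nothing available explains why the two rings differ.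

The compounds shown leave open how a 1H-pyrazol-4-yl group without its two methyl groups would stand, so the share of those methyl groups on this ring cannot be separated out. They also leave open what a methyl group on the pyrazole ring nitrogen, or an amine in place of one ring methyl group, would do, and whether the ring exchange carries over to the core of compound 2.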